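A new aryl group on a weak growth inhibitor

The source may report more compounds than this note shows. Statements on the series, on what has been measured and on what is new or still open speak of the compounds shown alone.

In a functional assay on HT-29 cells (Homo sapiens) (a higher number here means a weaker inhibitor of growth, a lower number a stronger inhibitor of growth), compound 1 (`O=S(=O)(/C=C/c1ccccc1)Cc1ccc(Nc2ncnc3ccccc23)cc1`) gives > 100000 nM as a limit of the assay. Compound 2 (`O=S(=O)(/C=C/c1ccc(Br)cc1)Cc1ccc(Nc2ncnc3ccccc23)cc1`) gives > 100000 nM as a limit too. Among the compounds with values here, compound 3 (`O=S(=O)(/C=C/c1ccc(Br)cc1)Cc1ccc(Nc2ncnc3ccc(Br)cc23)cc1`) gives 10000 nM as the only true number so far.

The change leading to compound 4 (`O=S(=O)(/C=C/c1ccc(C(F)(F)F)cc1F)Cc1ccc(Nc2ncnc3ccc(Br)cc23)cc1`) is 2-fluoro-4-(trifluoromethyl)phenyl in place of 4-bromophenyl on a double-bonded chain carbon bound to a double-bonded chain carbon and the rest of the molecule stays the same. Within the data shown here, two measured steps bear on it. The ring that changes here also changed in a step that the two limits leave unreadable from compound 1 to compound 2 and so offers no guide to size or direction. The clear gain came with an at least 10-fold lower number from compound 2 to compound 3 (1.00 log units; beyond the scatter) and that bromo, on the shared core, remains in compound 4. With that feature kept and no readable step on the changing ring, the expectation rests on compound 3 at 10000 nM and no shift beyond the scatter is foreseen. The estimated outcome is a 1.2-fold higher number from compound 3 to compound 4 (0.08 log units; within the scatter) in this assay with real uncertainty in either direction. Compound 4 is estimated at 12000 nM and expected to fall between 3000 nM and 50000 nM.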

Compound 4, concentration for 50% growth inhibition: 100000 nM
Estimate against measurement, compound 4: 8.3-fold (0.92 log units) below, and the stated range ends below it.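

The ring on the double-bonded chain carbon gave a step earlier that the two limits left unreadable, but here this assay shows a 10-fold higher number from compound 3 to compound 4 (1.00 log units; beyond the scatter) for this change. This position therefore responds to what it carries, and the shift is comparable in printed size to an at least 10-fold lower number from compound 2 to compound 3 (1.00 log units; beyond the scatter) but runs the opposite way. The bromo on the shared core does not secure a readable gain on its own, and compound 4 lands at the same figure as the assay's limit: the limit of > 100000 nM in this assay, at which 2 of the 4 values shown sit.

The fluoro and the trifluoromethyl enter together, so the compounds shown cannot separate their shares of the step. Going by these compounds, how a ring bearing an amine or a carboxylic acid would read also stays open, as does whether any ring here gives a lower number than compound 3 at 10000 nM does.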